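The compounds below may be only part of what the source reports. "The series", "measured", "known", "first", "only" and "open" are said of these compounds alone.

In an assay on cell membranes for binding affinity to Fatty-acid amide hydrolase 1 (Rattus norvegicus) (a higher number here means a weaker inhibitor, a lower number a stronger inhibitor), compound 1 `O=C(NC1CCCCC1)Oc1cccc(-c2cccc(Oc3ccccc3)c2)c1` gives 420 nM and compound 2 `O=C(NC1CCCCC1)Oc1cccc(-c2cccc(-c3ccccc3)c2)c1` gives 565 nM; these two sit within the scatter of each other, as a 1.3-fold higher number from compound 1 to compound 2 (0.13 log units; within the scatter) shows. Compound 3 `O=C(NC1CCCCC1)Oc1cccc(-c2cccc([N+](=O)[O-])c2)c1` gives 49.6 nM, the lowest of the three numbers; the steps onto it were an 8.5-fold lower number from compound 1 to compound 3 (0.93 log units; beyond the scatter) and an 11-fold lower number from compound 2 to compound 3 (1.06 log units; beyond the scatter). Compound 4 `N#Cc1cccc(-c2cccc(OC(=O)NC3CCCCC3)c2)c1` differs from compound 3 in one place: cyano in place of nitro on an aromatic carbon. For the measured compounds named here, no measured step exchanges one small group for another; both steps onto compound 3 swapped a larger group for nitro and lowered the number beyond the scatter. An exchange between two small groups is expected to move the number less, possibly not beyond the scatter. For compound 4 the estimate is 80 nM, with a range of 30 nM to 250 nM. The expected step is a 1.6-fold higher number from compound 3 to compound 4 (0.21 log units; within the scatter).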

Compound 4, half-maximal inhibitory concentration: 33.9 nM
The estimate for compound 4 lay 2.4-fold (0.37 log units) above the measured number, within the range that was stated.
By their numbers in this assay, from the lowest: compounds 4 and 3 (each within the scatter of the next); then compounds 1 and 2 (each within the scatter of the next).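

In this assay, for the compounds shown here, this is the only exchange between two small groups at this position, and a 1.5-fold lower number from compound 3 to compound 4 (0.17 log units; within the scatter) leaves cyano and nitro indistinguishable. Both a 12-fold lower number from compound 1 to compound 4 (1.09 log units; beyond the scatter) and a 17-fold lower number from compound 2 to compound 4 (1.22 log units; beyond the scatter) go the same way as the steps from those compounds to compound 3, so both small groups give lower numbers than phenoxy or phenyl. Nothing available explains this difference.

Still open, from the compounds shown here alone, is whether an amine, a carboxylic acid or a methyl group at this place would match cyano and nitro. Also open, going by these compounds, is how a chain of intermediate length would compare.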